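Aryl group exchange from compound 2 to compound 3

A few compounds are considered here, and "the series" means these few. Any claim that something is new, unique, unknown or untested is made for them only; others in the source may bear on it.

Values below come from a functional assay on MCF7 cells (Homo sapiens) for antiproliferative activity, read by CellTiter-Glo, with a stated time of 5 days; a higher number here means a weaker inhibitor, a lower number a stronger inhibitor

- compound 1 `N#Cc1cc(Cl)ccc1/C(=C(\c1ccc(/C=C/C(=O)O)cc1)c1ccc2scnc2c1)C1CCC1` gives 0.9 nM
- compound 2 `O=C(O)/C=C/c1ccc(/C(=C(\c2ccc(F)cc2Cl)C2CCC2)c2ccc3nccn3c2)cc1` gives 4.4 nM

Compound 2 has the higher of the two numbers at 4.4 nM and so is the weaker of the pair, its gap to compound 1 lying beyond the scatter. Compound 3 `N#Cc1cc(Cl)ccc1/C(=C(\c1ccc(/C=C/C(=O)O)cc1)c1ccc2nccn2c1)C1CCC1` takes 4-chloro-2-cyanophenyl in place of 2-chloro-4-fluorophenyl on a double-bonded chain carbon bound to a double-bonded chain carbon and a saturated ring carbon. Among the measured compounds shown here, no measured pair isolates this change. In this assay the estimated step is a 2.9-fold lower number from compound 2 to compound 3 (0.47 log units; beyond the scatter) and runs toward a lower number, modestly beyond the scatter. This expectation rests on compound 1, which carries the entering group on a different core and reads 0.9 nM in the same test. Compound 3 is estimated at 1.5 nM within a range from 0.5 nM to 4.5 nM on this evidence.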

Compound 3, half-maximal inhibitory concentration: 5.9 nM
Beside the measured number, compound 3's estimate is 3.9-fold (0.59 log units) below it, outside the stated range (above it).
By their numbers in this assay, from the lowest: compound 1; then compounds 2 and 3 (each within the scatter of the next).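

In this assay the exchange of 2-chloro-4-fluorophenyl for 4-chloro-2-cyanophenyl gives a 1.3-fold higher number from compound 2 to compound 3 (0.13 log units; within the scatter) and so, on the core shared by this pair, does not separate the two aryl groups at this position. With 4-chloro-2-cyanophenyl held constant, the core exchange gives a 6.6-fold higher number from compound 1 to compound 3 (0.82 log units; beyond the scatter) and so ties the low reading of compound 1 to its core and not to 4-chloro-2-cyanophenyl alone. No supporting measurement accounts for either step.

Still open, on these data alone, is whether a methoxy group or an amide could stand in place of the nitrile of 4-chloro-2-cyanophenyl on the core of compound 3. Also open, as far as these compounds go, is how 2-chloro-4-fluorophenyl reads on the core of compound 1, which would test whether the aryl exchange stays as small on that core.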